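Swapping a lactam for an aminopyrazole on the shared core

A few compounds are considered here, and "the series" means these few. Any claim that something is new, unique, unknown or untested is made for them only; others in the source may bear on it.

Compound 1 `O=C1CCCN1c1cnc(NCc2c(F)ccc3c2CCO3)c2cn[nH]c(=O)c12` is measured in an ADME assay on microsomes from liver (Homo sapiens) for metabolic stability, read by LC-MS, using NADPH, with stated times of 5 min and 30 min, tested at 1 uM (a higher number here means faster removal of the compound, a lower number slower removal), where compound 1 gives 23 mL.min-1.g-1. Compound 2 `CN(C)Cc1ccc2c(c1)CN(c1cnc(NCc3c(F)ccc4c3CCO4)n3cnnc13)C2=O` gives 19 mL.min-1.g-1 in this assay, and the gap between compound 1 and compound 2 lies within the usual scatter, so the two cannot be told apart. Among the measured compounds shown here, for compound 3 `CN(C(=O)c1ccccc1)c1cnc(NCc2c(F)ccc3c2CCO3)n2cnnc12` this assay reports only a limit, > 300 mL.min-1.g-1, not a number; it is the single value sitting at the limit of > 300 mL.min-1.g-1 in this assay, at which 1 of the 3 values shown sits. Compound 4 `CN(c1ccn(C)n1)c1cnc(NCc2c(F)ccc3c2CCO3)c2cn[nH]c(=O)c12` has not yet been measured in this assay. It differs from compound 1 in one place: methyl(1-methyl-1H-pyrazol-3-yl)amino in place of 2-oxopyrrolidin-1-yl on an aromatic carbon. For the measured compounds named here, no measured pair shows a step of this kind. Compound 4 is expected to be removed faster, with a step of a 2.6-fold higher number from compound 1 to compound 4 (0.42 log units; beyond the scatter) beyond the scatter. Compound 4 is estimated at 60 mL.min-1.g-1, with a range from 20 mL.min-1.g-1 to 200 mL.min-1.g-1.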

Compound 4, intrinsic clearance in microsomes: 62 mL.min-1.g-1
The estimate for compound 4 lay 1.0-fold (0.01 log units) below the measured number; the measured number falls inside the stated range.
By their numbers in this assay, from the lowest: compounds 2 and 1 (each within the scatter of the next); then compound 4. At a limit, above all of these: compound 3.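

In this assay, among the compounds shown here, replacing 2-oxopyrrolidin-1-yl with methyl(1-methyl-1H-pyrazol-3-yl)amino on this aromatic carbon gives the first one-place step: a 2.7-fold higher number from compound 1 to compound 4 (0.43 log units; beyond the scatter). The group carried at this position therefore changes how fast the compound is removed, though the step is modest in size. Nothing measured here accounts for the step. As far as these compounds go, it remains open whether the step follows from the pyrazole ring or from the methyl on the linking nitrogen, and how a secondary amine with hydrogen in place of that methyl, or a morpholine, would behave at this carbon.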